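A Phenyl Group Returns to the Sulfonyl Sulfur

The source may hold more compounds than are shown below. What is called first, only, known or untested is meant among the compounds shown, and "the series" means these compounds.

For the measured compounds named here, compound 3 `Cn1c(=O)c(S(=O)(=O)Nc2ccc(F)cc2F)cc2cnc(Nc3ccc4[nH]ccc4c3)nc21` gives 5000 nM in a functional assay on DU-145 cells (Homo sapiens) for inhibition, read by trypan blue exclusion, with a stated time of 72 h (on this read-out lower numbers stand for stronger inhibition and higher numbers for weaker inhibition), the highest of the three numbers measured so far; compound 1 `Cc1ccc(S(=O)(=O)c2cc3cnc(Nc4ccc5[nH]ccc5c4)nc3n(C)c2=O)cc1` gives 750 nM and compound 2 `Cn1c(=O)c(S(=O)(=O)c2ccc(O)cc2)cc2cnc(Nc3ccc4[nH]ccc4c3)nc21` gives 250 nM. Compound 4 `Cn1c(=O)c(S(=O)(=O)c2ccc(F)cc2N)cc2cnc(Nc3ccc4[nH]ccc4c3)nc21` differs from compound 3 by 2-amino-4-fluorophenyl in place of (2,4-difluorophenyl)amino on a sulfonyl sulfur. Going by the values given here, two measured steps bear on this change: a 6.7-fold higher number from compound 1 to compound 3 (0.82 log units; beyond the scatter) and a 20-fold higher number from compound 2 to compound 3 (1.30 log units; beyond the scatter), both of them rises when a (2,4-difluorophenyl)amino group took the place of a carbon-linked phenyl group on the sulfonyl sulfur. Undoing that swap should lower the number, and with a 3.0-fold lower number from compound 1 to compound 2 (0.48 log units; beyond the scatter) showing a 4-hydroxyphenyl group sitting lower than a 4-methylphenyl one, the 2-amino-4-fluorophenyl group with its one donor and one acceptor is expected to land between them. Compound 4 is therefore expected to show a 13-fold lower number from compound 3 to compound 4 (1.10 log units; beyond the scatter), with an estimated value of 400 nM in a range of 150 nM to 1200 nM.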

Compound 4, half-maximal inhibitory concentration: 3000 nM
The estimate for compound 4 lay 7.5-fold (0.88 log units) below the measured number, and the stated range ends below it.
By their numbers in this assay, from the lowest: compound 2; then compound 1; then compounds 4 and 3 (each within the scatter of the next).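

In this assay, a carbon-linked phenyl group on the sulfonyl sulfur is not enough on its own to give a low number: a 1.7-fold lower number from compound 3 to compound 4 (0.22 log units; within the scatter) stays within the scatter. The groups on that phenyl ring matter at this position, as a 4.0-fold higher number from compound 1 to compound 4 (0.60 log units; beyond the scatter) and a 12-fold higher number from compound 2 to compound 4 (1.08 log units; beyond the scatter) both lie beyond the scatter. Nothing available here accounts for this result. The compounds shown leave open where a plain phenyl group on the sulfonyl sulfur would stand, and which of the amino and fluoro groups of compound 4 goes with its higher number.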